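The source may report more compounds than this note shows. Statements on the series, on what has been measured and on what is new or still open speak of the compounds shown alone.

Three compounds share one core and differ only in the group on a saturated chain carbon, two bonds along the chain from an aromatic nitrogen. Compound 1 `CC(C)(N)C(=O)N[C@H](COCc1ccccc1)c1nnnn1CCC#N` gives 30 nM in a functional assay on H4 cells for agonist activity at growth hormone secretagogue receptor type 1 (Homo sapiens), read by FLIPR; a higher number here means that more compound is needed for the effect, a lower number that less compound is needed; compound 2 `CCCCNC(=O)CCn1nnnc1[C@@H](COCc1ccccc1)NC(=O)C(C)(C)N` gives 42 nM in this assay; compound 3 `CCCCNC(=O)CCCn1nnnc1[C@@H](COCc1ccccc1)NC(=O)C(C)(C)N` gives 30 nM in this assay. Compound 3 thus stands level with compound 1, the two together at the low end of these three numbers. Compound 4 `CC(C)(N)C(=O)N[C@H](COCc1ccccc1)c1nnnn1CCC(=O)NCCCc1ccccc1` carries (3-phenylpropyl)carbamoyl in place of (butylcarbamoyl)methyl on a saturated chain carbon, two bonds along the chain from an aromatic nitrogen. Because a 1.4-fold higher number from compound 1 to compound 2 (0.15 log units; within the scatter), no change at the digits printed from compound 1 to compound 3 (within the scatter) and a 1.4-fold lower number from compound 2 to compound 3 (0.15 log units; within the scatter), changes at this place have so far left the number essentially unmoved, and the same is expected here. For compound 4 the estimate is 30 nM, with a range from 12 nM to 75 nM. This amounts to an expected no change at the digits printed from compound 3 to compound 4 (within the scatter).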

Compound 4, half-maximal effective concentration: 59 nM
Compound 4: the middle estimate sits 2.0-fold (0.29 log units) below what was measured; low and high end bracket the measured number.
By their numbers in this assay, from the lowest: compounds 1, 3, 2 and 4 (each within the scatter of the next).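

The (3-phenylpropyl)carbamoyl group brings a six-membered aromatic ring to this place, yet a 2.0-fold higher number from compound 3 to compound 4 (0.29 log units; within the scatter) and a 2.0-fold higher number from compound 1 to compound 4 (0.29 log units; within the scatter) still leave this assay without a step beyond the scatter. Phenyl in place of methyl, on a saturated chain carbon, three bonds along the chain from an amide-type nitrogen, gives a 1.4-fold higher number from compound 2 to compound 4 (0.15 log units; within the scatter) and likewise stays within it. This place has therefore now held a nitrile and three different amide chains, one of them bearing an aromatic ring, with no clear shift.

As far as these compounds go, what a carboxylic acid or an amine would do here remains open. Nothing available explains this tolerance.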